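Stereochemical definition of a dioxolane-bearing analogue in the series

The compounds below may be only part of what the source reports. "The series", "measured", "known", "first", "only" and "open" are said of these compounds alone.

Measured so far in a functional assay on A-375 cells (Homo sapiens) for cytotoxicity, read by MTT assay, with a stated time of 72 h; a lower number here means a stronger inhibitor, a higher number a weaker inhibitor:
compound 1 `CN1CCN(CCCCCCn2c3c(c4ccccc42)C(=O)c2c[n+]([O-])c4ccccc4c2C3=O)CC1` gives 630 nM;
compound 2 `CC1(C)OCC(Cn2cc(Cn3c4c(c5ccccc53)C(=O)c3c[n+]([O-])c5ccccc5c3C4=O)nn2)O1` gives 330 nM;
compound 3 `O=C1c2c[n+]([O-])c3ccccc3c2C(=O)c2c1c1ccccc1n2CCCCN1CCCCC1` gives 190 nM.

Compound 2 stands second highest of the three numbers, with compound 3 within the scatter of it and compound 1 also within the scatter of it. Going by the values given here, the one step beyond the scatter, a 3.3-fold lower number from compound 1 to compound 3 (0.52 log units; beyond the scatter), changes a side-chain group and does not touch the ring carbon at issue here.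

Compound 4 `CC1(C)OC[C@@H](Cn2cc(Cn3c4c(c5ccccc53)C(=O)c3c[n+]([O-])c5ccccc5c3C4=O)nn2)O1` differs from compound 2 only as follows: the two compounds have the same atoms and bonds; at least one stereo element is drawn with a configuration in one of them and without one in the other: 1 of 1 stereo elements differ; a stereocentre at a saturated ring carbon is drawn without a configuration in compound 2 and R in compound 4. Among the compounds with values here, no measured step bears on this kind of change, since no pair in the set differs in a drawn configuration alone. With identical atoms and bonds, the step of no change at the digits printed from compound 2 to compound 4 (within the scatter) is expected to lie within the scatter, in no particular direction. Compound 4 is therefore estimated at 330 nM, ranging from 150 nM to 750 nM.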

Compound 4, half-maximal inhibitory concentration: 450 nM
The estimate for compound 4 lay 1.4-fold (0.13 log units) below the measured number; the range from low to high includes it.
By their numbers in this assay, from the lowest: compounds 3, 2, 4 and 1 (each within the scatter of the next, the first and the last beyond it).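

Going by these compounds alone, the first pair that differs only in a drawn configuration gives, in this assay, a 1.4-fold higher number from compound 2 to compound 4 (0.13 log units; within the scatter). Drawing the R configuration at this saturated ring carbon therefore leaves the number within the scatter of the compound drawn without one, the first reading at this position. The step rests on a single structural difference: the fact that one of compounds 2 and 4 is drawn with a defined configuration and the other without, at the place where they differ

Within the data shown here, compound 4 is the only compound with a drawn configuration here, so the S configuration at this carbon remains open. Also open, going by these compounds, is how a carboxylic acid or an amine would compare in place of the dioxolane.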